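Methoxy in Place of Methyl: An Expected Small Step

The source may hold more compounds than are shown below. What is called first, only, known or untested is meant among the compounds shown, and "the series" means these compounds.

Compound 1 `COc1ccc(S(=O)(=O)Oc2ccccc2/C=C(\C#N)C(=O)Nc2nnc(Cc3cccc4ccccc34)s2)cc1`: 29%
Compound 2 `Cc1ccc(S(=O)(=O)Oc2ccccc2/C=C(\C#N)C(=O)Nc2nnc(Cc3ccc(F)cc3)s2)cc1`: 16%

Going by the values given here, in an ADME assay on HEK-293T cells (Homo sapiens) for inhibition, read by CCK-8 assay, with a stated time of 48 h, tested at 20 uM (a higher number here means more inhibition of growth at the concentration tested, a lower number less inhibition of growth), compound 2 gives 16%, the lower of the two numbers measured so far. Compound 1 stands at 29%, higher by more than the usual scatter of repeated measurements.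

The next compound to be tested is compound 3 `COc1ccc(S(=O)(=O)Oc2ccccc2/C=C(\C#N)C(=O)Nc2nnc(Cc3ccc(F)cc3)s2)cc1`, which departs from compound 2 in one place: methoxy in place of methyl on an aromatic carbon. In words, this is methoxy in place of methyl on an aromatic carbon, para to a large group, so that 4-methylphenyl becomes 4-methoxyphenyl. The rest of the structure stays the same.

Among the compounds with values here, no two measured compounds differ in only one place, so the data give no direct measure of what this swap does in this assay. The expectation therefore stays close to compound 2 at 16%. The step of a number 3 percentage points higher from compound 2 to compound 3 (within the scatter) is expected to stay within the scatter, with only a slight lean upward. For compound 3 the estimated value is 19%, with an expected range from 7% to 32%.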

Compound 3, percent growth inhibition at one concentration: 20%
For compound 3 the middle estimate is 1 percentage points below the measured one; low and high end bracket the measured number.
By their numbers in this assay, from the lowest: compounds 2, 3 and 1 (each within the scatter of the next, the first and the last beyond it).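

In this assay, going by these compounds alone, methoxy in place of methyl on an aromatic carbon, para to a large group, gives a number 4 percentage points higher from compound 2 to compound 3 (within the scatter), the first direct reading of this swap: in this setting, 4-methylphenyl and 4-methoxyphenyl cannot be told apart, even though methoxy brings one more heavy atom and a hydrogen-bond acceptor. The second one-place change, 4-fluorophenyl in place of naphthalen-1-yl on a saturated chain carbon bound to an aromatic carbon, gives a number 9 percentage points lower from compound 1 to compound 3 (within the scatter), so on this evidence the larger naphthalen-1-yl group also cannot be separated from 4-fluorophenyl in this measurement. No measured evidence is available to explain either of these two small steps.

Going by these compounds, what remains open is whether a hydroxy group, an amine or a carboxylic acid in place of the methoxy group would also stay within the scatter of compound 2 and compound 3, or would move the number clearly. On these data alone, it also remains open whether methoxy in place of methyl would give an equally small step in a compound carrying naphthalen-1-yl at the other end of the molecule.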